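Removing a methyl from the oxygen of compound 3

The source may report more compounds than this note shows. Statements on the series, on what has been measured and on what is new or still open speak of the compounds shown alone.

Measured compounds and their values:
- compound 1, `COc1cc(C)cc(-c2c(-c3ccnc(-c4ccc(C(C)=O)cc4)c3)cnn2CC#N)c1`: 69%
- compound 2, `Cc1cc(O)cc(-c2nn(CC#N)cc2-c2ccnc(-c3ccc(Oc4ccccc4)cc3)c2)c1`: 59%
- compound 3, `COc1cc(C)cc(-c2nn(CC#N)cc2-c2ccnc(-c3ccc(N(C)C)cc3)c2)c1`: 93%

All three were tested in a functional assay on HOP-92 cells (Homo sapiens) for cytotoxicity, read by sulforhodamine B assay, with a stated time of 48 h, tested at 0.01 uM; a lower number here means a stronger effect, a higher number a weaker effect of the compound at the concentration tested. Compound 3 shows the highest number of the three, so the weakest effect. Its nearest neighbour on the numbers is compound 1, which lies a good way lower, beyond the usual scatter, and compound 2 lies lower still, also beyond the scatter. Compound 1 and compound 2 differ from compound 3 in more than one place, so their gaps cannot be tied to a single change.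

The next compound, compound 4, `Cc1cc(O)cc(-c2nn(CC#N)cc2-c2ccnc(-c3ccc(N(C)C)cc3)c2)c1`, is separated from compound 3 by just one change: hydrogen in place of methyl on an oxygen on an aromatic ring. Put another way, a methoxy group on the shared core becomes a hydroxy group.

Among the measured compounds shown here, no measured pair carries exactly this change, so there is no step to lean on. The expectation is that the step from compound 3 to compound 4 in this assay, a number 11 percentage points lower from compound 3 to compound 4 (beyond the scatter), is small, at most a modest move toward a stronger effect, and quite possibly nothing beyond the scatter. Compound 4 is therefore expected to give about 82%, within a range from 62% to 100%.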

Compound 4, a percentage reported as activity, at one concentration (the size of the read-out at that concentration, not a potency): 85%
The estimate for compound 4 lay 3 percentage points below the measured number, and the stated range covers the measured number.
By their numbers in this assay, from the lowest: compounds 2 and 1 (each within the scatter of the next); then compounds 4 and 3 (each within the scatter of the next).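

Among the compounds shown here, compound 4 gives the first direct reading of the methoxy group on the shared core: in this assay, hydrogen in place of methyl on the oxygen gives a number 8 percentage points lower from compound 3 to compound 4 (within the scatter), so at this single concentration the methoxy and hydroxy forms cannot be told apart. For the compounds shown here, it also gives the first clean reading of the group at the far end of the molecule: with the 3-hydroxy-5-methylphenyl group the same in both compounds, dimethylamino in place of phenoxy on an aromatic carbon gives a number 26 percentage points higher from compound 2 to compound 4 (beyond the scatter), a weaker effect and a step that stands clear of the usual variation between repeats. Nothing available explains either result.

Going by these compounds, it remains open whether the oxygen tolerates more than these two forms, for example a longer chain such as ethoxy, or whether an amine or a carboxylic acid in place of the hydroxy would also leave this assay unmoved. On these data alone, it is also open whether the step from phenoxy to dimethylamino would be the same size on a core that carries methoxy rather than hydroxy.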